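This account rests on a few compounds, and the source may have more. Where it says the series, first, only, none or still open, it means among the compounds named here.

Compound 1 `Cc1csc(-c2cc(C(O)(C(F)(F)F)C(F)(F)F)cnc2N2CCN(S(=O)(=O)c3ccc(N)nc3)CC2)c1` shares its core with compound 2 `NC(=O)c1cccc(-c2cc(C(O)(C(F)(F)F)C(F)(F)F)cnc2N2CCN(S(=O)(=O)c3ccc(N)nc3)CC2)c1` and with compound 3 `COc1ccc(-c2cc(C(O)(C(F)(F)F)C(F)(F)F)cnc2N2CCN(S(=O)(=O)c3ccc(N)nc3)CC2)cn1`, which has not yet been measured. In an ADME assay (liver) for metabolic stability, with Liver microsome (Homo sapiens) as the target, using microsomes and NADPH, with a stated time of 30 min, tested at 1 uM (on this read-out higher numbers stand for fast clearance and lower numbers for slow clearance), compound 1 gives 29 mL.min-1.g-1, the higher of the two numbers on record, while compound 2 gives 17 mL.min-1.g-1. Within the data shown here, the one step measured so far, a 1.7-fold lower number from compound 1 to compound 2 (0.23 log units; within the scatter), therefore stays inside the scatter. The step to compound 3 is a different exchange on the same aromatic carbon: 6-methoxypyridin-3-yl in place of 4-methylthiophen-2-yl on an aromatic carbon. Among the measured compounds shown here, no measured step involves the group that enters here, so the only guide is that one swap at this position left this assay essentially unchanged. On that basis the step of a 1.5-fold lower number from compound 1 to compound 3 (0.16 log units; within the scatter) is expected to be small, leaning if anything toward a lower number. Compound 3 is thus estimated to give 20 mL.min-1.g-1 in this assay, with a likely range from 9 mL.min-1.g-1 to 45 mL.min-1.g-1.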

Compound 3, intrinsic clearance in microsomes: 25 mL.min-1.g-1
Estimate against measurement, compound 3: 1.3-fold (0.10 log units) below; measured number inside the range.
By their numbers in this assay, from the lowest: compounds 2, 3 and 1 (each within the scatter of the next).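

In this assay, replacing 4-methylthiophen-2-yl with 6-methoxypyridin-3-yl makes a second exchange on this aromatic carbon that stays within the scatter (a 1.2-fold lower number from compound 1 to compound 3 (0.06 log units; within the scatter)), and the exchange of 3-carbamoylphenyl for 6-methoxypyridin-3-yl does the same (a 1.5-fold higher number from compound 2 to compound 3 (0.17 log units; within the scatter)). Where one step had been available before, three pairs now show that 4-methylthiophen-2-yl, 3-carbamoylphenyl and 6-methoxypyridin-3-yl cannot be told apart on this read-out. No supporting evidence is available to explain this result.

The compounds shown leave open whether a group of another kind on this carbon, such as an amine, a carboxylic acid or a longer alkyl chain, would move the clearance beyond the scatter. They also leave open how changes elsewhere on the shared core would affect it.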